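Replacing an isopropylpiperazine with a methylpiperidine on a shared core

A few compounds are considered here, and "the series" means these few. Any claim that something is new, unique, unknown or untested is made for them only; others in the source may bear on it.

The study follows a small series of sulfonamide-linked amides in an ADME assay on microsomes from liver (Homo sapiens) for metabolic stability, with a stated time of 30 min, tested at 1 uM; a lower number here means that less of the compound is left, a higher number that more of the compound is left. Compound 1, `COc1cc(C)c(S(=O)(=O)N(C)CCOCC(=O)N2CCC(N3CCN(C(C)C)CC3)CC2)c(C)c1`, gives 54% in this assay, the lowest of the three numbers recorded. Compound 3, `COc1cc(C)c(S(=O)(=O)N(C)CCOCC(=O)N2CCN(CC3CCN(C)CC3)CC2)c(C)c1`, gives 86%, and compound 2, `CN(Cc1ccc(C2=NCCN2)cc1)C(=O)COCCN(C)S(=O)(=O)c1c(F)cccc1F`, gives 87%; both of these lie beyond the scatter above compound 1, so compound 1 stands clearly apart at the low end.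

The step under examination leads from compound 1 to compound 4, `COc1cc(C)c(S(=O)(=O)N(C)CCOCC(=O)N2CCC(C3CCN(C)CC3)CC2)c(C)c1`, which has not yet been measured in this assay. The change is 1-methylpiperidin-4-yl in place of 4-isopropylpiperazin-1-yl on a saturated ring carbon. For the measured compounds named here, no measured pair in the set differs in this single place, so nothing seen so far fixes the size of the step. Given that compound 3, which also carries a 1-methylpiperidin-4-yl fragment, reaches 86%, the author expects an upward move of moderate size, a number 14 percentage points higher from compound 1 to compound 4 (beyond the scatter), likely beyond the scatter but not guaranteed to be. Compound 4 is estimated at 68%, within 45% to 88%.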

Compound 4, percent of the compound remaining: 23%
For compound 4 the middle estimate is 45 percentage points above the measured one, and the stated range ends above it.
By their numbers in this assay, from the lowest: compound 4; then compound 1; then compounds 3 and 2 (each within the scatter of the next).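

In this assay, for the compounds shown here, exchanging 4-isopropylpiperazin-1-yl for 1-methylpiperidin-4-yl on a saturated ring carbon gives a number 31 percentage points lower from compound 1 to compound 4 (beyond the scatter) and is the first step in the set that changes a single place. It shows that this position, three ring bonds from the ring nitrogen, is not indifferent to the group it carries: with the shared core unchanged, the entering group leaves clearly less of the compound. Nothing measured here bears on why the number falls.

This single pair cannot separate the loss of one ring nitrogen from the exchange of isopropyl for methyl, since both change together. From the compounds shown here alone, it remains open whether 4-methylpiperazin-1-yl at the same saturated ring carbon would stand nearer compound 1 or compound 4.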